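This account rests on a few compounds, and the source may have more. Where it says the series, first, only, none or still open, it means among the compounds named here.

Working notes on a short halogenated series. Compound 1 `Clc1cccc(/N=N/N2CCCCC2)c1` and compound 2 `Brc1cccc(/N=N/N2CCCCC2)c1` share a core; compound 3 `Clc1ccc(/N=N/N2CCCC2)cc1` and the not yet measured compound 4 `Brc1ccc(/N=N/N2CCCC2)cc1` share another; the difference between the two cores is not broken down here. In an ADME assay on MT4 cells (Homo sapiens) for cytotoxicity, read by MTT assay, with a stated time of 96 h (on this read-out higher numbers stand for lower toxicity in this test and lower numbers for higher toxicity in this test), compound 1 gives > 100000 nM, which is a limit of the assay and not a number. Compound 2 gives > 100000 nM in this assay, likewise a limit. Compound 3 gives > 100000 nM in this assay, also a limit. Within the data shown here, the change bromo in place of chloro on an aromatic carbon produced a step that the two limits leave unreadable from compound 1 to compound 2; the only evidence here is the limit of > 100000 nM in this assay, at which 3 of the 3 values shown sit. The change bromo in place of chloro on an aromatic carbon is the same kind of change, but the place differs: meta to a group of 8 heavy atoms in compound 1, para to a group of 7 heavy atoms in compound 3. Compound 4 is expected to sit at the same limit, so the expected step is a step that the limit leaves unreadable from compound 3 to compound 4, resting on compound 3 giving > 100000 nM. The estimate for compound 4 in this assay is 150000 nM, between 80000 nM and 300000 nM.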

Compound 4, half-maximal cytotoxic concentration: > 100000 nM
Compound 4 was reported as a limit; the forecaster's own chance of this, stated with the estimate: 85%; the middle value is on the limit's open side.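

Compound 3 and compound 4 both sit at a limit of the assay, so no step can be read between them, nor between compound 1 and compound 2: the limit of > 100000 nM in this assay, at which 4 of the 4 values shown sit.

The compounds shown leave open whether bromo in place of chloro changes anything in this assay, and at what concentration any of the four turns toxic.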